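This account rests on a few compounds, and the source may have more. Where it says the series, first, only, none or still open, it means among the compounds named here.

In a functional assay on L1210 cells (Mus musculus) for cytotoxicity, with a stated time of 48 h (on this read-out lower numbers stand for stronger inhibition and higher numbers for weaker inhibition), compound 1 `CCCC#Cc1cn([C@@H]2O[C@H](CO)[C@@H](O)[C@H](O)[C@H]2O)c(=O)[nH]c1=O` gives 115000 nM, a high number that marks only weak inhibition of the cells. Compound 3 `CCCc1cc2cn([C@@H]3O[C@H](CO)[C@@H](O)[C@H](O)[C@H]3O)c(=O)nc2o1` gives 132000 nM, and this value lies within the usual scatter of that of compound 1, so the two cannot be told apart. Compound 2 `C#Cc1cn([C@@H]2O[C@H](CO)[C@@H](O)[C@H](O)[C@H]2O)c(=O)nc1N` has no exact number, only a limit of the assay, >= 250000 nM. Compound 1 therefore shares the only measured level with compound 3, and nothing shown so far reaches strong inhibition.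

The next compound to be tested is compound 4 `O=c1[nH]c(=O)n([C@@H]2O[C@H](CO)[C@@H](O)[C@H](O)[C@H]2O)cc1C#Cc1cccnc1`. It keeps the core of compound 1 and has pyridin-3-yl in place of propyl on a triple-bonded carbon. The pent-1-yn-1-yl group thus becomes 2-(pyridin-3-yl)ethynyl.

Within the data shown here, no measured pair shows this change on its own, so the expectation leans on the general level of the values, with compound 1 at 115000 nM as the starting point. The expected step in this assay, a 1.3-fold higher number from compound 1 to compound 4 (0.12 log units; within the scatter), is small, perhaps no larger than the scatter, and if anything leans towards weaker inhibition. A result reported only as a limit would not be surprising. For compound 4 the estimated value is 150000 nM, with an expected range from 70000 nM to 250000 nM.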

Compound 4, half-maximal inhibitory concentration: > 250000 nM
Compound 4: no number, only a limit; the forecaster's own chance of this, stated with the estimate: 35%; middle value at least 1.6-fold (0.22 log units) from the limit.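

In this assay, replacing propyl with pyridin-3-yl on a triple-bonded carbon, which turns pent-1-yn-1-yl into 2-(pyridin-3-yl)ethynyl, gives an at least 2.1-fold higher number from compound 1 to compound 4 (0.33 log units; beyond the scatter). Among these compounds, this is the first comparison here between two compounds that differ in only one place, and it shows that changing the group at the far end of the triple bond can shift the read-out beyond the scatter, towards weaker inhibition of the cells. The true size of the step remains unknown, because compound 4 has only a limit of the assay and no exact number: the limit of > 250000 nM in this assay, at which 1 of the 4 values shown sits.

A single step cannot separate the possible roles of the ring itself, its nitrogen atom and the larger size of the new group, so a phenyl group or a longer chain such as hexyl at the same place would be informative. Going by these compounds, it also remains open whether any group on the triple-bonded carbon can bring the cytotoxicity of this series from the weak level of compound 1, at 115000 nM, to strong inhibition.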